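From methyl to 4-methylpiperazin-1-yl on the shared core

The source may hold more compounds than are shown below. What is called first, only, known or untested is meant among the compounds shown, and "the series" means these compounds.

Compound 1 `Cc1ccc(NC(=O)C2CCN(C/C=C/c3ccccc3)CC2)cc1`: 30000 nM
Compound 2 `COc1ccc(NC(=O)C2CCN(C/C=C/c3ccccc3)CC2)cc1`: > 100000 nM (a limit of the assay)
Compound 3 `O=C(Nc1cccc(C(F)(F)F)c1)C1CCN(C/C=C/c2ccccc2)CC1`: 16100 nM

In a functional assay on MCF7 cells (Homo sapiens) for inhibition, read by MTT assay, with a stated time of 72 h (a higher number here means a weaker inhibitor, a lower number a stronger inhibitor), compound 1 at 30000 nM and compound 3 at 16100 nM lie within the scatter of each other. The entry for compound 2 is a limit, not a number. Compound 4 `CN1CCN(c2ccc(NC(=O)C3CCN(C/C=C/c4ccccc4)CC3)cc2)CC1` has 4-methylpiperazin-1-yl in place of methyl on an aromatic carbon, para to a large group: 4-methylpiperazin-1-yl in place of methyl on an aromatic carbon. One measured step replaces that methyl: an at least 3.3-fold higher number from compound 1 to compound 2 (0.52 log units; beyond the scatter), beyond the scatter and resting on (the limit of > 100000 nM in this assay, at which 1 of the 3 values shown sits). That step brought in methoxy, a different group, so it is only a loose guide and sets no firm direction here. The estimated step is a 1.2-fold lower number from compound 1 to compound 4 (0.08 log units; within the scatter), which would lie within the scatter. For compound 4 the expected value is 25000 nM, with an estimated range from 6000 nM to 100000 nM.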

Compound 4, half-maximal inhibitory concentration: 44000 nM
The estimate for compound 4 lay 1.8-fold (0.25 log units) below the measured number, within the range that was stated.
By their numbers in this assay, from the lowest: compounds 3, 1 and 4 (each within the scatter of the next, the first and the last beyond it). At a limit, above all of these: compound 2.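

Replacing methyl with 4-methylpiperazin-1-yl on this aromatic carbon, para to a large group, gives a 1.5-fold higher number from compound 1 to compound 4 (0.17 log units; within the scatter) in this assay, so even this much larger group with its own ring leaves the result within the scatter of compound 1. The second step is an at least 2.2-fold lower number from compound 2 to compound 4 (0.35 log units; beyond the scatter), so methoxy and 4-methylpiperazin-1-yl do not read alike at this position. Compound 2 stands at a limit, so that step gives only a bound: the limit of > 100000 nM in this assay, at which 1 of the 4 values shown sits.

As far as these compounds go, whether a carboxylic acid or a simple dimethylamino group here would also stay within the scatter of compound 1 remains open. So does how 4-methylpiperazin-1-yl would read in the place held by trifluoromethyl in compound 3.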